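A few compounds are considered here, and "the series" means these few. Any claim that something is new, unique, unknown or untested is made for them only; others in the source may bear on it.

Of the compounds shown here, three have been measured in a functional assay on HEK293 cells for agonist activity at D(4) dopamine receptor (Homo sapiens), read by FLIPR; on this read-out higher numbers stand for an effect only at larger amounts of compound and lower numbers for an effect already at smaller amounts. Compound 1 `O=C(NCN1CCC(c2cccc[n+]2[O-])CC1)c1ccccc1` gives 532 nM in this assay, and compound 2 `Cc1cccc(NC(=O)CN2CCC(c3cccc(F)c3)CC2)c1` gives 512 nM. Compound 3 `Cc1cc(C)cc(NC(=O)CN2CCC(c3cccc[n+]3[O-])CC2)c1` gives 52 nM, the lowest of the three numbers; its gap to compound 2 and its gap to compound 1 both lie beyond the usual scatter of repeated measurements, so compound 3 stands apart as the one that acts at the smallest amounts among these three.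

Compound 4 `Cc1cc(NC(=O)CN2CCC(c3cccc[n+]3[O-])CC2)ccc1F` has not yet been measured. It differs from compound 3 in one place: 4-fluoro-3-methylphenyl in place of 3,5-dimethylphenyl on an amide-type nitrogen. Within the data shown here, no measured pair in this set shows the effect of such a swap, so the size of the step cannot be read from earlier numbers. Since the rest of compound 3 is kept, the change is expected to be modest, most likely a small move toward larger amounts, though a step within the scatter would not surprise. The step from compound 3 to compound 4 is thus estimated at a 2.9-fold higher number from compound 3 to compound 4 (0.46 log units; beyond the scatter). For compound 4 the expected value in this assay is 150 nM, with a likely range from 50 nM to 500 nM.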

Compound 4, half-maximal effective concentration: 18 nM
For compound 4 the middle estimate is 8.3-fold (0.92 log units) above the measured one; the whole stated range lies above it.
By their numbers in this assay, from the lowest: compound 4; then compound 3; then compounds 2 and 1 (each within the scatter of the next).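

In this assay the group on the amide-type nitrogen proves to be a place where a small edit moves the number, with the rest of the molecule kept the same (a 2.9-fold lower number from compound 3 to compound 4 (0.46 log units; beyond the scatter)). The leaving 3,5-dimethylphenyl and the entering 4-fluoro-3-methylphenyl each hold one aromatic carbon ring and have the same number of heavy atoms, so a step beyond the usual scatter arises here even though those counts stay the same. Nothing available explains why this swap lowers the number.

The compounds shown leave open how much of the step belongs to the added fluorine and how much to the lost methyl. They also leave open how a 4-chloro-3-methylphenyl group or a plain phenyl group on this nitrogen would compare.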